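The compounds below may be only part of what the source reports. "The series", "measured", "known", "first", "only" and "open" are said of these compounds alone.

In an ADME assay on L1210/0 cells (Mus musculus) for cytotoxicity, with a stated time of 48 h (a lower number here means a stronger inhibitor, a higher number a weaker inhibitor), the measured compounds are:

Compound 1 `O=c1[nH]c(=O)n([C@H]2C[C@H](O)[C@@H](CO)O2)cc1/C=C/I` gives 63900 nM
Compound 2 `Nc1ncnc2c1nnn2[C@@H]1C[C@H](CO)[C@@H](CO)[C@H]1CO` gives > 200000 nM (a limit of the assay)
Compound 3 `Nc1ncnc2c1ncn2[C@@H]1C[C@@H]2COC[C@H]2[C@H]1CO` gives > 200000 nM (a limit of the assay)

Among the measured compounds shown here, compound 1 stands alone here as the only compound with an actual number. The other two readings define the limit of > 200000 nM in this assay, at which 2 of the 3 values shown sit, and give no exact values. With so little data, compound 1 can only be placed as a single measured point, and its value is the natural starting point for anything that follows.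

The next compound, compound 4 `N#Cc1cn([C@H]2C[C@H](O)[C@@H](CO)O2)c(=O)[nH]c1=O`, keeps the core of compound 1 and has cyano in place of 2-iodoethenyl on an aromatic carbon on the ring. For the measured compounds named here, no measured pair in this small set shows what such a swap does, so any forecast is a judgement. The expectation starts from compound 1 at 63900 nM in this assay and leans towards a weaker inhibitor, by a moderate amount. The estimated change is a 2.7-fold higher number from compound 1 to compound 4 (0.42 log units; beyond the scatter) and it could carry the reading to the limit of the assay, leaving no exact number. For compound 4 the estimated value is 170000 nM with an expected range from 40000 nM to 500000 nM in this measurement.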

Compound 4, half-maximal inhibitory concentration: > 200000 nM
Compound 4: a limit, no number (the forecaster's own chance of this, stated with the estimate: 55%); at least 1.1-fold (0.07 log units) between middle value and limit.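

In this assay compound 4 gives > 200000 nM, which is a limit and not a number. On this aromatic carbon of the shared core, cyano in place of 2-iodoethenyl gives an at least 3.1-fold higher number from compound 1 to compound 4 (0.49 log units; beyond the scatter), the first sign that this position affects the reading, and this swap moves it towards a weaker inhibitor by more than the scatter. The true size of the step stays unknown, and only its lower bound can be read, because compound 4 now sits with most of the set at the same limit: the limit of > 200000 nM in this assay, at which 3 of the 4 values shown sit.

The compounds shown leave open whether it is the 2-iodoethenyl group as a whole that holds compound 1 at a measurable number, or whether a single iodine atom, an ethyl group, a longer carbon chain, an amine or a carboxylic acid on this same carbon would do as well or better. They also rest on a single swap at a single position, so nothing can yet be said about how other parts of the core of compound 1 affect the reading.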